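Ester to Amide on a Shared Core: Expected Potency

The source may report more compounds than this note shows. Statements on the series, on what has been measured and on what is new or still open speak of the compounds shown alone.

Three compounds sharing one core were measured in an assay on HEK293 cells for displacement of a labelled ligand from NPC1-like intracellular cholesterol transporter 1 (Homo sapiens); a higher number here means a weaker inhibitor, a lower number a stronger inhibitor. Compound 1 `NC(=O)C1CCCN(C(=O)CN2CN(c3ccccc3)C3(CCN(C(=O)c4ccc(C5CCCCC5)cc4)CC3)C2=O)C1` gives 3100 nM. Compound 2 `CCOC(=O)C1CCCN(C(=O)CN2CN(c3ccccc3)C3(CCN(C(=O)c4ccc(C(C)(C)C)cc4)CC3)C2=O)C1` gives 8200 nM, and compound 3 `CCOC(=O)C1CCCN(C(=O)CN2CN(c3ccccc3)C3(CCN(C(=O)c4ccc(C5CCCCC5)cc4)CC3)C2=O)C1` gives 4200 nM. Compound 3 and compound 1 differ by amino in place of ethoxy on a carbonyl carbon and the step was a 1.4-fold lower number from compound 3 to compound 1 (0.13 log units; within the scatter). The cores of compound 3 and compound 2 differ by tert-butyl in place of cyclohexyl on an aromatic carbon, with the step of a 2.0-fold lower number from compound 2 to compound 3 (0.29 log units; within the scatter). Compound 4 `CC(C)(C)c1ccc(C(=O)N2CCC3(CC2)C(=O)N(CC(=O)N2CCCC(C(N)=O)C2)CN3c2ccccc2)cc1` is not yet measured; it differs from compound 2 by amino in place of ethoxy on a carbonyl carbon, the same change as from compound 3 to compound 1, at a place described in the same words. Because the earlier step of a 1.4-fold lower number from compound 3 to compound 1 (0.13 log units; within the scatter) stayed within the scatter, compound 4 is expected to show a step of a 1.4-fold lower number from compound 2 to compound 4 (0.14 log units; within the scatter). Compound 4 is therefore estimated at 6000 nM, likely between 2500 nM and 14000 nM.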

Compound 4, half-maximal inhibitory concentration: 16900 nM
Beside the measured number, compound 4's estimate is 2.8-fold (0.45 log units) below it, and the stated range ends below it.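

In this assay, with tert-butyl on the aromatic carbon, amino in place of ethoxy gave a 2.1-fold higher number from compound 2 to compound 4 (0.31 log units; beyond the scatter), so this change did not carry over unchanged from the cyclohexyl pair: the same change on two cores in this assay, a 1.4-fold lower number (0.13 log units; within the scatter) from compound 3 to compound 1 and a 2.1-fold higher number (0.31 log units; beyond the scatter) from compound 2 to compound 4, 2.8-fold (0.45 log units) apart, beyond the scatter of two such steps

Likewise, with the carbamoyl group in place, tert-butyl in place of cyclohexyl gave a 5.5-fold higher number from compound 1 to compound 4 (0.74 log units; beyond the scatter), a larger step than in the ethoxycarbonyl pair: the same change on two cores in this assay, a 2.0-fold lower number (0.29 log units; within the scatter) from compound 2 to compound 3 and a 5.5-fold lower number (0.74 log units; beyond the scatter) from compound 4 to compound 1, 2.8-fold (0.45 log units) apart, beyond the scatter of two such steps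

So in these four compounds the size of each change depends on the group at the other place, but this does not show why, nor whether the same holds for other groups.

On these data alone, whether a carboxylic acid or an N-methyl amide at that carbonyl carbon would follow the cyclohexyl pair or the tert-butyl pair remains open.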